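The source may report more compounds than this note shows. Statements on the series, on what has been measured and on what is new or still open speak of the compounds shown alone.

Measured so far, in an assay on isolated protein for inhibition of Amine oxidase [flavin-containing] B (Homo sapiens); on this read-out higher numbers stand for weaker inhibition and lower numbers for stronger inhibition:
compound 1 `CCN(CCCCCCOc1ccc(C(=O)/C=C/c2ccc(N(C)C)cc2)c(O)c1)Cc1ccccc1` gives 2100 nM
compound 2 `CCN(CCCCCCOc1ccc(C(=O)/C=C/c2ccc(N(C)C)cc2)c(O)c1)Cc1ccccc1N(C)C` gives 2100 nM
compound 3 `CCN(CCCOc1ccc(C(=O)/C=C/c2ccccc2)c(O)c1)Cc1ccccc1N(C)C` gives 800 nM

From compound 1 to compound 2 the change is dimethylamino in place of hydrogen on an aromatic carbon and the step is no change at the digits printed from compound 1 to compound 2 (within the scatter). Compound 3 sits on a different core; the difference between the two cores is not broken down here, and compound 3 stands lowest of the three in this assay, beyond the scatter from both compound 1 and compound 2.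

Compound 4 `CCN(CCCOc1ccc(C(=O)/C=C/c2ccc(N(C)C)cc2)c(O)c1)Cc1ccccc1N(C)C` is not yet measured. It arises from compound 3 by dimethylamino in place of hydrogen on an aromatic carbon. This is the same kind of change as from compound 1 to compound 2, not the same: there the entering group sits ortho to a large group, here para to a large group. Given no change at the digits printed from compound 1 to compound 2 (within the scatter), the expected step is no change at the digits printed from compound 3 to compound 4 (within the scatter), and compound 4 is estimated at 800 nM with a range from 400 nM to 1600 nM.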

Compound 4, half-maximal inhibitory concentration: 3200 nM
Beside the measured number, compound 4's estimate is 4.0-fold (0.60 log units) below it; the whole stated range lies below it.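

In this assay, dimethylamino in place of hydrogen does not carry over unchanged between these two cores: the same change on two cores in this assay, no change at the digits printed (within the scatter) from compound 1 to compound 2 and a 4.0-fold higher number (0.60 log units; beyond the scatter) from compound 3 to compound 4, 4.0-fold (0.60 log units) apart, beyond the scatter of two such steps. On the core of compound 3, with the group entering para to a large group, the change gives a 4.0-fold higher number from compound 3 to compound 4 (0.60 log units; beyond the scatter), so the flat step on the core of compound 1 cannot serve as a rule for the series. With one pair per core, the data do not show whether the difference follows the place of entry, the chain length or the rest of the core.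

Open, from the compounds shown here alone, is whether methoxy or a primary amine at the same place on the core of compound 3 gives a step of similar size. Also open, going by these compounds, is how the step behaves on a core with a chain of intermediate length.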